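Trimming a hydroxyethoxy group back to methoxy

A few compounds are considered here, and "the series" means these few. Any claim that something is new, unique, unknown or untested is made for them only; others in the source may bear on it.

Of the compounds shown here, three with a shared core have been measured, and a fourth awaits measurement. Compound 1 `O=C(O)c1cccc([C@H]2C[C@@H](c3ccc(OCc4c(-c5c(Cl)cccc5Cl)noc4C4CC4)cc3Cl)C2)c1` carries only hydrogen on the saturated ring carbon in question, and in an assay on HEK293 cells for agonist activity at Bile acid receptor (Homo sapiens) (a higher number here means a larger maximal response, a lower number a smaller maximal response), compound 1 gives 88%. Compound 2 `CCO[C@]1(c2ccc(OCc3c(-c4c(Cl)cccc4Cl)noc3C3CC3)cc2Cl)C[C@H](c2cccc(C(=O)O)c2)C1` carries an ethoxy group there, and compound 2 gives 89%. Compound 3 `O=C(O)c1cccc([C@H]2C[C@](OCCO)(c3ccc(OCc4c(-c5c(Cl)cccc5Cl)noc4C4CC4)cc3Cl)C2)c1` carries a 2-hydroxyethoxy group, and compound 3 gives 68%, the lowest of the three numbers.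

Among the measured steps, the ethoxy in place of hydrogen gave a number 1 percentage points higher from compound 1 to compound 2 (within the scatter), whereas the 2-hydroxyethoxy in place of hydrogen gave a number 20 percentage points lower from compound 1 to compound 3 (beyond the scatter), and adding the hydroxy to the ethoxy chain gave a number 21 percentage points lower from compound 2 to compound 3 (beyond the scatter).

Compound 4 `CO[C@]1(c2ccc(OCc3c(-c4c(Cl)cccc4Cl)noc3C3CC3)cc2Cl)C[C@H](c2cccc(C(=O)O)c2)C1` differs from compound 3 as follows: hydrogen in place of hydroxymethyl on a saturated chain carbon bound to an oxygen on a saturated carbon. This removes the hydroxy-bearing carbon that separated compound 3 from compound 2, leaving a methoxy that resembles the ethoxy of compound 2. For the measured compounds named here, because the step of a number 21 percentage points lower from compound 2 to compound 3 (beyond the scatter) was the one change that pulled the response down, its reversal is expected to raise it by about a number 19 percentage points higher from compound 3 to compound 4 (beyond the scatter). Compound 4 is therefore estimated to give 87%, with a range from 72% to 97%.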

Compound 4, largest response reached (reported as efficacy), in percent of the reference or control that the assay uses: 75%
Compound 4: middle estimate off by 12 percentage points, on the high side; measured number inside the range.
By their numbers in this assay, from the lowest: compounds 3 and 4 (each within the scatter of the next); then compounds 1 and 2 (each within the scatter of the next).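

In this assay, cutting the 2-hydroxyethoxy back to methoxy leaves a response that cannot be told apart from that of the hydroxy compound (a number 7 percentage points higher from compound 3 to compound 4 (within the scatter)), so at this position, losing the hydroxymethyl does not on its own bring the response back up to the level of the ethoxy compound. The single methyl at the end of the ethoxy chain turns out to matter as well (a number 14 percentage points lower from compound 2 to compound 4 (beyond the scatter)), and methoxy on the saturated ring carbon also stands apart from plain hydrogen (a number 13 percentage points lower from compound 1 to compound 4 (beyond the scatter)), so hydrogen and ethoxy sit together while methoxy and 2-hydroxyethoxy sit together, and the response does not simply fall or rise as the group on this carbon grows. Nothing available here explains why one extra methyl separates methoxy from ethoxy at this carbon.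

The compounds shown leave open whether a longer chain such as propoxy would stay with ethoxy or drop away from it. They also leave open what a hydroxy placed directly on the ring carbon, or an amine at the end of the ethoxy chain, would do.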